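The source may hold more compounds than are shown below. What is called first, only, known or untested is meant among the compounds shown, and "the series" means these compounds.

Compound 1 `Fc1ccc(C2=NN(C(=S)Nc3ccccc3)C(c3ccc4c(c3)OCCO4)C2)cc1` in a functional assay on HCT-116 cells (Homo sapiens) for antiproliferative activity, read by MTT assay, with a stated time of 48 h (a lower number here means a stronger inhibitor of growth, a higher number a weaker inhibitor of growth), gives 61200 nM. Compound 2 `O=[N+]([O-])c1ccc(C2=NN(C(=S)Nc3ccccc3)C(c3ccc4c(c3)OCCO4)C2)cc1` carries nitro in place of fluoro, and its reading in this assay, > 200000 nM, is a limit of the assay and not a number. The step of an at least 3.2-fold higher number from compound 1 to compound 2 (0.51 log units; beyond the scatter) is bounded by the limit of > 200000 nM in this assay, at which 1 of the 2 values shown sits. Compound 2 thus stands at the weaker end of the two values shown. Compound 3 `S=C(Nc1ccccc1)N1N=C(c2ccc(OCc3ccccc3)cc2)CC1c1ccc2c(c1)OCCO2` differs from compound 2 by benzyloxy in place of nitro on an aromatic carbon. Within the data shown here, only the step from compound 1 to compound 2 bears on this change, and it concerned a different group, so the direction remains uncertain; a move back toward the value of compound 1 is expected, an at least 2.8-fold lower number from compound 2 to compound 3 (0.45 log units; beyond the scatter). Compound 3 is therefore estimated at 70000 nM, within 15000 nM to 300000 nM.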

Compound 3, concentration for 50% growth inhibition: 8530 nM
The estimate for compound 3 lay 8.2-fold (0.91 log units) above the measured number, and the stated range ends above it.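

Benzyloxy on this aromatic carbon, para to a large group, gives a 7.2-fold lower number from compound 1 to compound 3 (0.86 log units; beyond the scatter) in this assay, so a substituent carrying its own six-membered aromatic ring goes with stronger growth inhibition than fluoro. Against nitro the change reads as an at least 23-fold lower number from compound 2 to compound 3 (1.37 log units; beyond the scatter), a bound only, since the reading of compound 2 is a limit of the assay and not a number: the limit of > 200000 nM in this assay, at which 1 of the 3 values shown sits.

The compounds shown leave open whether the gain follows the ether oxygen or the added aromatic ring. A methoxy, a phenyl or an amine at this place would separate these readings.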